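Will Iodo Shift the Numbers for Compound 4?

The source may report more compounds than this note shows. Statements on the series, on what has been measured and on what is new or still open speak of the compounds shown alone.

In a functional assay on K562 cells (Homo sapiens) for cytotoxicity, read by XTT assay, with a stated time of 24 h (a lower number here means a stronger inhibitor, a higher number a weaker inhibitor), compound 2 `Cc1ccc(NC(=O)c2ccccc2OCCCCn2ccnc2)cc1Nc1nccc(-c2cccnc2)n1` gives 47500 nM while compound 1 `Cc1ccc(NC(=O)c2ccc(Br)cc2OCCCCn2ccnc2)cc1Nc1nccc(-c2cccnc2)n1` gives 66100 nM and compound 3 `Cc1ccc(NC(=O)c2cc(I)ccc2OCCCCn2ccnc2)cc1Nc1nccc(-c2cccnc2)n1` gives 66500 nM in the same test. Compound 2 thus stands within the usual scatter of both other compounds, and these numbers do not rank the three.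

Compound 4 `Cc1ccc(NC(=O)c2ccc(I)cc2OCCCCn2ccnc2)cc1Nc1nccc(-c2cccnc2)n1` is still unmeasured and carries one change from compound 2, namely iodo in place of hydrogen on an aromatic carbon with everything else the same. This is iodo in place of hydrogen on an aromatic carbon, meta to a 4-(1H-imidazol-1-yl)butoxy group and para to a large group.

Among the measured compounds shown here, two measured steps bear on this change. One is a 1.4-fold lower number from compound 1 to compound 2 (0.14 log units; within the scatter) where bromo at that same place gives way to hydrogen. The other is a 1.4-fold higher number from compound 2 to compound 3 (0.15 log units; within the scatter) where iodo enters at a different carbon of that ring. Both steps are small, so no shift beyond the scatter is expected here. The expected step is a 1.3-fold higher number from compound 2 to compound 4 (0.10 log units; within the scatter) in this assay and would stay within the scatter. For compound 4 the estimated value is 60000 nM with an expected range from 35000 nM to 100000 nM for this measurement.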

Compound 4, half-maximal inhibitory concentration: 57400 nM
The estimate for compound 4 lay 1.0-fold (0.02 log units) above the measured number; the measured number falls inside the stated range.
By their numbers in this assay, from the lowest: compounds 2, 4, 1 and 3 (each within the scatter of the next).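

In this assay, iodo on this carbon gives a 1.2-fold higher number from compound 2 to compound 4 (0.08 log units; within the scatter) and, with iodo in place of bromo at the same carbon, a 1.2-fold lower number from compound 1 to compound 4 (0.06 log units; within the scatter), so neither step leaves the scatter. Among the compounds shown here, until now, this carbon, meta to a 4-(1H-imidazol-1-yl)butoxy group and para to a large group, had been seen only with hydrogen and bromo; iodo now joins them, and this test does not tell the three apart. No supporting measurement is available to explain these numbers.

With only hydrogen and two halogens shown at this carbon, it remains open whether a quite different group there, such as an amine, a carboxylic acid or a methoxy group, would move the number beyond the scatter. From the compounds shown here alone, the 4-(1H-imidazol-1-yl)butoxy group is also the same in all four compounds, so the effect of a shorter or longer chain in its place, or of another ring in place of the imidazole, remains open too.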